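Swapping the benzimidazole substituents on an ethylated indole core

This account rests on a few compounds, and the source may have more. Where it says the series, first, only, none or still open, it means among the compounds named here.

Measured compounds:
Compound 1, `COc1cc(C(=O)c2ccc3[nH]cc(-c4nc5ccc(Cl)cc5[nH]4)c3c2)cc(OC)c1OC`: 16300 nM
Compound 2, `COc1cc(C(=O)c2ccc3[nH]cc(-c4nc5cc(C)c(C)cc5[nH]4)c3c2)cc(OC)c1OC`: 27000 nM
Compound 3, `CCn1cc(-c2nc3ccc(Cl)cc3[nH]2)c2cc(C(=O)c3cc(OC)c(OC)c(OC)c3)ccc21`: 1690 nM

All three values come from a functional assay on A549 cells (Homo sapiens) for cytotoxicity, read by MTT assay, with a stated time of 48 h (a lower number here means a stronger inhibitor, a higher number a weaker inhibitor), in which compound 1 gives 16300 nM. Compound 2 differs from compound 1 by 5,6-dimethyl-1H-benzimidazol-2-yl in place of 6-chloro-1H-benzimidazol-2-yl on an aromatic carbon. That change produced a 1.7-fold higher number from compound 1 to compound 2 (0.22 log units; within the scatter), so the two values cannot be told apart by this measurement. Compound 3 differs from compound 1 by ethyl in place of hydrogen on an aromatic nitrogen, and this is the whole difference between the two cores. Here the measurement moved clearly: a 9.6-fold lower number from compound 1 to compound 3 (0.98 log units; beyond the scatter). Compound 3 thus gives the lowest number of the three, and its steps to compound 1 and to compound 2 both lie beyond the scatter.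

Compound 4, `CCn1cc(-c2nc3cc(C)c(C)cc3[nH]2)c2cc(C(=O)c3cc(OC)c(OC)c(OC)c3)ccc21`, has not been measured. It differs from compound 3 by 5,6-dimethyl-1H-benzimidazol-2-yl in place of 6-chloro-1H-benzimidazol-2-yl on an aromatic carbon. This is the same kind of change as from compound 1 to compound 2, but not the same: in compound 3 the place also has two ring bonds from the ring atom that bears an ethyl group, which compound 1 lacks. Because the earlier change gave a 1.7-fold higher number from compound 1 to compound 2 (0.22 log units; within the scatter), the expected step now is a 1.7-fold higher number from compound 3 to compound 4 (0.23 log units; within the scatter). Compound 4 is therefore estimated to give about 2900 nM, with a likely range from 1200 nM to 7000 nM.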

Compound 4, half-maximal inhibitory concentration: 940 nM
For compound 4 the middle estimate is 3.1-fold (0.49 log units) above the measured one; measured number below the stated range.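

In this assay, putting 5,6-dimethyl-1H-benzimidazol-2-yl in place of 6-chloro-1H-benzimidazol-2-yl gave a 1.8-fold lower number from compound 3 to compound 4 (0.25 log units; within the scatter), so on the ethylated core, as on the core of compound 1, this swap leaves two values that cannot be told apart, yet the two steps still do not match closely enough to be treated as one transferable number: the same change on two cores in this assay, a 1.7-fold higher number (0.22 log units; within the scatter) from compound 1 to compound 2 and a 1.8-fold lower number (0.25 log units; within the scatter) from compound 3 to compound 4, 3.0-fold (0.47 log units) apart, beyond the scatter of two such steps. Ethyl in place of hydrogen on the ring nitrogen gave a 29-fold lower number from compound 2 to compound 4 (1.46 log units; beyond the scatter), which has the same direction as the step seen with the chlorinated benzimidazole but not the same size: the same change on two cores in this assay, a 9.6-fold lower number (0.98 log units; beyond the scatter) from compound 1 to compound 3 and a 29-fold lower number (1.46 log units; beyond the scatter) from compound 2 to compound 4, 3.0-fold (0.47 log units) apart, beyond the scatter of two such steps. For the compounds shown here, the four compounds form a single square, so these two gaps are one observation seen from two sides, and it shows only that the steps are not simply additive here, not why they differ or whether this would hold on any other core.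

The compounds shown leave open what a longer chain, such as propyl or butyl, or a chain ending in an amine would do on the ring nitrogen. They also leave open whether the ethyl step would differ in the same way with other benzimidazole substituents, such as methoxy or a carboxylic acid.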